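The compounds below may be only part of what the source reports. "The series", "measured", "known", "first", "only" and "open" are said of these compounds alone.

In a toxicity assay on cells (Fibroblast, Homo sapiens) for cytotoxicity (a lower number here means a stronger inhibitor, a higher number a weaker inhibitor), compound 1 `CC(/C=C/C1=CCCCC1(C)C)=C\C=C\C(C)=C\COC(=O)c1c(O)cccc1O` gives 14000 nM and compound 2 `CC(/C=C/C1=CCCCC1(C)C)=C\C=C\C(C)=C\COC(=O)c1cc(O)c2ccccc2c1O` gives 420000 nM as its reading. Compound 1 therefore has the lower of the two numbers, and the gap lies beyond the usual scatter. Compound 3 `CC(=O)Oc1ccccc1C(=O)OC/C=C(C)/C=C/C=C(C)/C=C/C1=CCCCC1(C)C` is still unmeasured. It carries 2-acetoxyphenyl in place of 2,6-dihydroxyphenyl on a carbonyl carbon, and 2-acetoxyphenyl in place of 2,6-dihydroxyphenyl on a carbonyl carbon gives the count of that change. Among the measured compounds shown here, no measured pair shows this swap, so the expectation is loose: a moderate move beyond the scatter towards a higher number, meaning a weaker inhibitor. The expected step runs a 4.3-fold higher number from compound 1 to compound 3 (0.63 log units; beyond the scatter) on this reasoning. Compound 3 is estimated at 60000 nM with a likely range from 12000 nM to 300000 nM in this assay.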

Compound 3, half-maximal inhibitory concentration: 150000 nM
Estimate against measurement, compound 3: 2.5-fold (0.40 log units) below; the range from low to high includes it.
By their numbers in this assay, from the lowest: compound 1; then compound 3; then compound 2.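

On the carbonyl carbon, putting 2-acetoxyphenyl in place of 2,6-dihydroxyphenyl gives a large move in this assay with an 11-fold higher number from compound 1 to compound 3 (1.03 log units; beyond the scatter) and so shows that the number at this position depends strongly on the group it carries. The entering group counts 0 hydrogen-bond donors against 2 for the leaving group, and it also has more heavy atoms, so the step cannot be assigned to either difference. Nothing available here explains the rise. Going by these compounds, it remains open whether the step follows the loss of the hydroxyl groups or the arrival of the acetoxy group. A methoxy group or an amine on the same ring could help to separate the two.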